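The source may hold more compounds than are shown below. What is called first, only, known or untested is meant among the compounds shown, and "the series" means these compounds.

For the measured compounds named here, compound 2 `COc1ccccc1-n1nc([C@@H]2CCO[C@@H](C(C)C)C2)cc1-c1ccc(Cl)cc1` stands highest of the two numbers measured so far in an assay on HEK293 cells for inhibition of Voltage-dependent N-type calcium channel subunit alpha-1B (Homo sapiens), read by fluorescence and calcium flux, with a stated time of 5 min; a higher number here means a weaker inhibitor, a lower number a stronger inhibitor: compound 2 gives 20 nM, while its nearest neighbour, compound 1 `COc1ccccc1-n1nc(C2CCOC(C)(C)C2)cc1-c1ccc(Cl)cc1`, gives 2 nM in this assay. Going by the values given here, the single measured step, a 10-fold higher number from compound 1 to compound 2 (1.00 log units; beyond the scatter), came from swapping the 2,2-dimethyloxan-4-yl group for the 2-isopropyloxan-4-yl group on an aromatic carbon of the shared core. Compound 3 `COc1ccccc1-n1nc(C2=CC(C)(C)OC(C)(C)C2)cc1-c1ccc(Cl)cc1` changes that same position again: a group of 10 heavy atoms (9 carbon, 1 oxygen; one six-membered non-aromatic ring with 1 hetero atom) in place of a group of 9 heavy atoms (8 carbon, 1 oxygen; one six-membered non-aromatic ring with 1 hetero atom), on an aromatic carbon. The entering ring carries methyl groups and a double bond rather than the isopropyl group, so in its substitution pattern it is closer to the ring of compound 1 than to that of compound 2. Among the compounds with values here, only the step from compound 1 to compound 2 bears on this change, and it was beyond the scatter. Within the data shown here, the expected step of a 2.5-fold lower number from compound 2 to compound 3 (0.40 log units; beyond the scatter) is toward a lower number in this assay because compound 1 gives 2 nM, though the extra methyl groups and the double bond have no measured precedent here. Compound 3 is therefore estimated at 8 nM, with a likely range from 2 nM to 40 nM.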

Compound 3, half-maximal inhibitory concentration: 3 nM
Compound 3: middle estimate off by 2.7-fold (0.43 log units), on the high side; the measured number falls inside the stated range.
By their numbers in this assay, from the lowest: compounds 1 and 3 (each within the scatter of the next); then compound 2.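

In this assay, putting the new ring with its methyl groups and double bond in place of the 2-isopropyloxan-4-yl group gives a 6.7-fold lower number from compound 2 to compound 3 (0.82 log units; beyond the scatter) and so recovers most of the ground lost with the isopropyl ring. Set against the 2,2-dimethyloxan-4-yl group, the same ring gives a 1.5-fold higher number from compound 1 to compound 3 (0.18 log units; within the scatter) and leaves compound 1 and compound 3 impossible to tell apart in this test, which shows that this aromatic carbon of the shared core tolerates a ring of 10 heavy atoms containing a double bond as well as it does the ring of compound 1. Among these three compounds, the ring carrying the isopropyl group stands apart, but no further measurement explains why the three rings read as they do.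

The new ring differs from the isopropyl ring in both its methyl groups and its double bond, so the share of each in the step cannot be separated from these compounds. As far as these compounds go, it also remains open how a piperidine ring, which has a nitrogen where these rings have oxygen, or an oxane ring bearing a carboxylic acid would read at this position.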